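The source may hold more compounds than are shown below. What is called first, only, known or untested is meant among the compounds shown, and "the series" means these compounds.

Compound 1 `COc1cc(CN(CC(=O)NCc2ccccc2Cl)S(=O)(=O)c2ccc(CN3CCCCC3)cc2)ccc1OCC(C)C`: 267 nM
Compound 2 `COc1cc(CN(CC(=O)NCc2ccccc2Cl)S(=O)(=O)c2ccc(CN3CCN(C)CC3)cc2)ccc1OCC(C)C`: 37 nM

Both compounds share the same core and differ only in the amine attached to a saturated chain carbon bound to an aromatic carbon. In an in vitro functional assay on COS-7 cells for antagonist activity at B1 bradykinin receptor (Homo sapiens), read by calcium flux (a higher number here means a weaker inhibitor, a lower number a stronger inhibitor), compound 1 gives 267 nM, and compound 2 gives 37 nM. For the measured compounds named here, compound 2 therefore stands at the lowest number of the two, and the one measured step, a 7.2-fold lower number from compound 1 to compound 2 (0.86 log units; beyond the scatter), comes from putting 4-methylpiperazin-1-yl in place of piperidin-1-yl at that position.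

Compound 3 `COc1cc(CN(CC(=O)NCc2ccccc2Cl)S(=O)(=O)c2ccc(CN(C)C)cc2)ccc1OCC(C)C` carries the change (dimethylamino in place of 4-methylpiperazin-1-yl on a saturated chain carbon bound to an aromatic carbon). Going by the values given here, the ring is given up for an open dimethylamino group, a change not tested in any measured pair, so the one step available bears on it only loosely: it shows that the amine at this position can move the number by a modest amount. With the ring gone, compound 3 is expected to sit between the two measured compounds, though the direction is uncertain. Compound 3 is estimated at 90 nM in this assay, with a range of 25 nM to 330 nM. The expected step is a 2.4-fold higher number from compound 2 to compound 3 (0.39 log units; beyond the scatter).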

Compound 3, inhibition constant: 497 nM
Compound 3: middle estimate off by 5.5-fold (0.74 log units), on the low side, and the stated range ends below it.
By their numbers in this assay, from the lowest: compound 2; then compounds 1 and 3 (each within the scatter of the next).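

In this assay, giving up the 4-methylpiperazin-1-yl ring for the open dimethylamino group brings a 13-fold higher number from compound 2 to compound 3 (1.13 log units; beyond the scatter) and this large step shows that the low number of compound 2 is easily lost at this position. Set against piperidin-1-yl, the same dimethylamino group gives a 1.9-fold higher number from compound 1 to compound 3 (0.27 log units; within the scatter) so these two amines cannot be told apart here, even though one carries a ring and the other does not. Among these three amines, then, having a ring does not by itself go with a low number: only the 4-methylpiperazin-1-yl group does, and no data at hand explain why.

As far as these compounds go, what remains open is which part of the 4-methylpiperazin-1-yl group matters, the second ring nitrogen or the methyl on it. Piperazin-1-yl, which lacks that methyl, 4-ethylpiperazin-1-yl, which has a longer chain in its place, and morpholin-4-yl, which has an oxygen instead of the second nitrogen, would each help to separate these possibilities on the same shared core.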